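The compounds below may be only part of what the source reports. "The series", "measured", "known", "first", "only" and "open" are said of these compounds alone.

Series notes. For the measured compounds named here, in a functional assay on CHO cells for antagonist activity at prostaglandin E2 receptor EP3 subtype (Homo sapiens), read by cAMP accumulation (a higher number here means a weaker inhibitor, a lower number a stronger inhibitor), compound 2 `CC(C)C(c1ccc(-c2ccc3cccc(F)c3c2)[nH]c1=O)N1CCCCS1(=O)=O` gives 122 nM, the second highest of the three numbers measured so far. Compound 1 `CCC(CC)(c1nnc[nH]1)c1ccc(-c2ccc3cc(F)cc(F)c3c2)[nH]c1=O` gives 350 nM, and compound 3 `CCn1ncc2c(F)cc(-c3ccc(C(CC)(CC)c4nnc[nH]4)c(=O)[nH]3)cc21` gives 29 nM. Compound 2 therefore sits between the two, and its gaps to compound 1 and to compound 3 both lie beyond the usual scatter. Going by the values given here, compounds 1 and 3 carry a different group at the same saturated chain carbon, and they differ from compound 2 elsewhere as well, so no measured pair in this set isolates the exchange at that carbon.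

Compound 4 `CC(C)C(c1ncco1)c1ccc(-c2ccc3cccc(F)c3c2)[nH]c1=O` is compound 2 with the change (a group of 5 heavy atoms (3 carbon, 1 nitrogen, 1 oxygen; one five-membered aromatic ring with 2 hetero atoms) in place of a group of 8 heavy atoms (4 carbon, 1 nitrogen, 2 oxygen, 1 sulfur; one six-membered non-aromatic ring with 2 hetero atoms), on a saturated chain carbon bound to an aromatic carbon and a saturated chain carbon). Among the compounds with values here, no measured step matches this exchange. Within the data shown here, compound 1 at 350 nM and compound 3 at 29 nM show only that other groups at this carbon fall on either side of compound 2. A modest step in this assay is expected, direction uncertain, possibly none beyond the scatter. The step from compound 2 to compound 4 is estimated at a 1.6-fold higher number from compound 2 to compound 4 (0.21 log units; within the scatter). Compound 4 is expected to give 200 nM, within a range of 60 nM to 700 nM.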

Compound 4, half-maximal inhibitory concentration: 64 nM
Beside the measured number, compound 4's estimate is 3.1-fold (0.49 log units) above it; low and high end bracket the measured number.
By their numbers in this assay, from the lowest: compound 3; then compounds 4 and 2 (each within the scatter of the next); then compound 1.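

In this assay, 1,3-oxazol-2-yl in place of the six-membered non-aromatic ring with 2 hetero atoms, on a saturated chain carbon bound to an aromatic carbon and a saturated chain carbon, gives a 1.9-fold lower number from compound 2 to compound 4 (0.28 log units; within the scatter). For the compounds shown here, this is the first pair that isolates an exchange at this carbon, and it shows that a five-membered aromatic ring of 5 heavy atoms and a sulfur-bearing non-aromatic ring of 8 heavy atoms can stand here with no difference beyond the scatter. Nothing on hand gives a cause for this result.

The compounds shown leave open whether a group at this carbon with no ring, such as an amine or a carboxylic acid, would keep the number in this assay close to those of compound 2 and compound 4. They also do not tell how the group at this carbon in compound 1 and compound 3 would read on the core of compound 2.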